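Permeability Outlook for a Hept-1-en-1-yl Analogue

A few compounds are considered here, and "the series" means these few. Any claim that something is new, unique, unknown or untested is made for them only; others in the source may bear on it.

Measured compounds:
compound 1 `COc1cc2[nH]c(C)c(C3CCCCC3)c(=O)c2cc1Cl`: 630 10^-6 cm/s
compound 2 `COc1cc2[nH]c(C)c(Br)c(=O)c2cc1Cl`: 152 10^-6 cm/s

Of the compounds shown here, two have been measured in an ADME assay for permeability, using PAMPA, at pH 7.4; on this read-out lower numbers stand for lower permeability and higher numbers for higher permeability; compound 1 gives 630 10^-6 cm/s and compound 2 gives 152 10^-6 cm/s. Among the measured compounds shown here, compound 2 therefore stands at the lower of the two numbers, with compound 1 as its only neighbour, separated by the single known step, a 4.1-fold lower number from compound 1 to compound 2 (0.62 log units; beyond the scatter).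

Compound 3 `CCCCC/C=C/c1c(C)[nH]c2cc(OC)c(Cl)cc2c1=O` is the next member, unmeasured in this assay. It differs from compound 2 in one place: hept-1-en-1-yl in place of bromo on an aromatic carbon. The step of a 4.1-fold lower number from compound 1 to compound 2 (0.62 log units; beyond the scatter) is the one that bears on this change, since there a cyclohexyl ring of carbons gave way to bromo and the number fell. The change to compound 3 runs the other way, bromo giving way to a chain of carbons, so a rise back toward compound 1 is expected, estimated as a 3.3-fold higher number from compound 2 to compound 3 (0.52 log units; beyond the scatter). Compound 3 is thus expected to give about 500 10^-6 cm/s, within 250 10^-6 cm/s to 950 10^-6 cm/s.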

Compound 3, apparent permeability: 46.3 10^-6 cm/s
For compound 3 the middle estimate is 11-fold (1.03 log units) above the measured one; measured number below the stated range.
By their numbers in this assay, from the lowest: compound 3; then compound 2; then compound 1.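

In this assay the move to hept-1-en-1-yl gives a 3.3-fold lower number from compound 2 to compound 3 (0.52 log units; beyond the scatter) and so shows that, at this position, bromo does not mark the low end of the series and a carbon group can read lower than a halogen. Replacing one carbon group with another here gives a 14-fold lower number from compound 1 to compound 3 (1.13 log units; beyond the scatter) and is a large step, so the high number of the cyclohexyl compound does not carry over to an open chain. No measurement at hand accounts for this result.

The compounds shown leave open whether the low number goes with the double bond, the length of the chain or the absence of a ring. From the compounds shown here alone, how a shorter saturated chain such as propyl, or a chain ending in an amine, would read at this position also remains open.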